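The source may hold more compounds than are shown below. What is called first, only, known or untested is meant among the compounds shown, and "the series" means these compounds.

Measured compounds:
compound 1 `CC1(C)[C@H]2CC[C@]1(C)N(Cc1cn(-c3ccccc3F)nn1)C(=O)C2`: 60 nM
compound 2 `CC1(C)[C@H]2CC[C@]1(C)N(Cc1cn(-c3ccccc3Cl)nn1)C(=O)C2`: 60 nM
compound 3 `CC1(C)[C@H]2CC[C@]1(C)N(Cc1cn(-c3ccccc3)nn1)C(=O)C2`: 90 nM

In a functional assay on HepG2 cells (Homo sapiens) for inhibition, read by MTT assay, with a stated time of 24 h (a higher number here means a weaker inhibitor, a lower number a stronger inhibitor), compound 3 carries the highest of the three numbers, yet the gaps to its two neighbours are a 1.5-fold higher number from compound 1 to compound 3 (0.18 log units; within the scatter) and a 1.5-fold higher number from compound 2 to compound 3 (0.18 log units; within the scatter), both within the scatter, so the three compounds cannot be ranked against one another on these data. The remaining step, no change at the digits printed from compound 1 to compound 2 (within the scatter), likewise shows nothing beyond the scatter.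

Compound 4 `COc1ccc(-n2cc(CN3C(=O)C[C@@H]4CC[C@@]3(C)C4(C)C)nn2)cc1` differs from compound 3 in one place: methoxy in place of hydrogen on an aromatic carbon. Among the measured compounds shown here, no measured step introduces a methoxy group, so the change itself is untested here. What the series does show is that swapping a halogen for hydrogen on the phenyl ring, in a 1.5-fold higher number from compound 1 to compound 3 (0.18 log units; within the scatter) and a 1.5-fold higher number from compound 2 to compound 3 (0.18 log units; within the scatter), left this assay unchanged within the scatter. For the measured compounds named here, on that basis the expected step is a 1.1-fold higher number from compound 3 to compound 4 (0.05 log units; within the scatter), meaning no shift beyond the scatter, with the range widened because the methoxy substitution has no direct precedent among the measured compounds. Compound 4 is therefore estimated at 100 nM, between 40 nM and 300 nM.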

Compound 4, half-maximal inhibitory concentration: 100 nM
Estimate against measurement, compound 4: no gap at the digits printed; low and high end bracket the measured number.
By their numbers in this assay, from the lowest: compounds 1, 2, 3 and 4 (each within the scatter of the next).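

In this assay, among the compounds shown here, the change from phenyl to 4-methoxyphenyl gives a 1.1-fold higher number from compound 3 to compound 4 (0.05 log units; within the scatter) and so adds the first reading for a group para to a large group, where the earlier compounds varied only hydrogen, fluoro and chloro on the ring. Set against the halogen-bearing rings, the exchange for 4-methoxyphenyl gives a 1.7-fold higher number from compound 2 to compound 4 (0.22 log units; within the scatter) from 2-chlorophenyl and a 1.7-fold higher number from compound 1 to compound 4 (0.22 log units; within the scatter) from 2-fluorophenyl, so all four aryl groups remain within the scatter of one another. No supporting information on hand bears on this result.

For the compounds shown here, no step yet lies beyond the scatter, so the limits of what this ring accepts stay undefined. Open questions are whether an amine, a carboxylic acid or a longer alkoxy chain at the same place would shift the number.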